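Swapping an Acid-Bearing Ring for a Chlorophenyl Group

The compounds below may be only part of what the source reports. "The series", "measured", "known", "first", "only" and "open" are said of these compounds alone.

Of the compounds shown here, three have been measured so far in an ADME assay on PBMC cells (Homo sapiens) for cytotoxicity; on this read-out higher numbers stand for lower toxicity in this test and lower numbers for higher toxicity in this test. Compound 1 `Cc1cccc(OC(c2ccc(Br)cc2)C2CCN(C(C)CCNC(=O)c3c(Cl)cncc3Cl)CC2)n1` gives 6500 nM. Compound 2 `CC(CCNC(=O)c1c(Cl)cncc1Cl)N1CCC(C(Oc2cccc(C(=O)O)n2)c2ccc(C(F)(F)F)cc2)CC1` gives 28700 nM, the higher of the two true numbers, and the gap between these two compounds lies beyond the usual scatter. Compound 3 `CCO/N=C(/c1ccc(Br)cc1)C1CCN(C(C)CCN(C)C(=O)c2c(C)cc[n+]([O-])c2C)CC1` gives > 182000 nM, which is a limit of the assay and not a number.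

The next compound to follow is compound 4 `CC(CCNC(=O)c1c(Cl)cncc1Cl)N1CCC(C(Oc2cccc(Cl)c2)c2ccc(C(F)(F)F)cc2)CC1`, which differs from compound 2 in one place: 3-chlorophenyl in place of 6-carboxypyridin-2-yl on an oxygen on a saturated carbon. Put simply, 3-chlorophenyl stands in place of 6-carboxypyridin-2-yl on an oxygen on a saturated carbon. Within the data shown here, no measured pair shows this change directly, so any forecast has to lean on a loose comparison. The closest guide is compound 1 at 6500 nM, which also has no carboxy group on the ring attached to that oxygen, although it differs from compound 4 elsewhere as well. A lower number is therefore expected in this assay, meaning higher toxicity in this test. The expected change is a 4.8-fold lower number from compound 2 to compound 4 (0.68 log units; beyond the scatter), a drop estimated to lie beyond the scatter. For compound 4 the estimated value is 6000 nM, with an expected range from 2000 nM to 18000 nM.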

Compound 4, half-maximal cytotoxic concentration: 8100 nM
Beside the measured number, compound 4's estimate is 1.4-fold (0.13 log units) below it; the range from low to high includes it.
By their numbers in this assay, from the lowest: compounds 1 and 4 (each within the scatter of the next); then compound 2. At a limit, above all of these: compound 3.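

In this assay, replacing 6-carboxypyridin-2-yl with 3-chlorophenyl gives a 3.5-fold lower number from compound 2 to compound 4 (0.55 log units; beyond the scatter), a modest change that still lies beyond the scatter and points to higher toxicity in this test. The earlier compounds shown here differ from one another in more than one place, so none of their gaps could be tied to this position alone; this pair differs only in the group on this oxygen, which shows that this group can shift the read-out. The swap removes a hydrogen-bond donor, hydrogen-bond acceptors and a ring nitrogen and brings in a chlorine, all in one move, and no measurement given here explains the drop.

From the compounds shown here alone, it remains open which part of the swap matters most: a phenyl ring carrying a carboxylic acid, or a pyridin-2-yl ring carrying a chlorine, would help separate the acid from the ring nitrogen. Whether an amine on this ring would shift the number in the same direction, in the opposite direction or not at all is also unknown.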